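Five-membered and six-membered aryl groups replacing methanesulfonamido

The compounds below may be only part of what the source reports. "The series", "measured", "known", "first", "only" and "open" are said of these compounds alone.

Measured so far in a functional assay on CHO cells for agonist activity at Alpha-1A adrenergic receptor (Homo sapiens), read by FLIPR and calcium flux; on this read-out higher numbers stand for larger maximal responses and lower numbers for smaller maximal responses:
compound 1, `CS(=O)(=O)Nc1cccc2c1CCC2c1ncc[nH]1`: compound 1 gives 87%
compound 2, `c1cc(-c2cn[nH]c2)c2c(c1)C(c1ncc[nH]1)CC2`: compound 2 gives 84%
compound 3, `c1cncc(-c2cccc3c2CCC3c2ncc[nH]2)c1`: compound 3 gives 36%

Compound 1 holds the highest number of the three, though compound 2 sits within the scatter of it (a number 3 percentage points lower from compound 1 to compound 2 (within the scatter)), while compound 3 lies far lower (a number 51 percentage points lower from compound 1 to compound 3 (beyond the scatter)). Compound 4 is `c1cc(-c2ncco2)c2c(c1)C(c1ncc[nH]1)CC2` and differs from compound 1 by 1,3-oxazol-2-yl in place of methanesulfonamido on an aromatic carbon. For the measured compounds named here, two steps bear on it: the step to compound 2, a change to a five-membered aromatic ring, cost nothing beyond the scatter, whereas the step to compound 3, a change to a six-membered aromatic ring, was large. Compound 4 carries a five-membered ring without a hydrogen-bond donor, so a moderate fall is expected, a number 25 percentage points lower from compound 1 to compound 4 (beyond the scatter). Compound 4 is therefore estimated at 62%, within 30% to 90%.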

Compound 4, largest response reached (Emax), in percent of the reference or control that the assay uses: 63%
For compound 4 the middle estimate is 1 percentage points below the measured one; the measured number falls inside the stated range.
By their numbers in this assay, from the lowest: compound 3; then compound 4; then compounds 2 and 1 (each within the scatter of the next).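

In this assay the 1,3-oxazol-2-yl group gives an intermediate response at this aromatic carbon: a number 24 percentage points lower from compound 1 to compound 4 (beyond the scatter) and a number 21 percentage points lower from compound 2 to compound 4 (beyond the scatter) but a number 27 percentage points higher from compound 3 to compound 4 (beyond the scatter). The five-membered rings of compound 2 and compound 4 therefore do not match, so ring size alone does not set the maximal response here. No measurement at hand accounts for these differences.

As far as these compounds go, it remains open whether a 1,3-thiazol-2-yl group would track the 1,3-oxazol-2-yl group. From the compounds shown here alone, the response with an amine or a carboxylic acid on this carbon also remains open.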